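The compounds below may be only part of what the source reports. "The series", "measured", "known", "first", "only" and "open" are said of these compounds alone.

Compound 3 `Cc1cn(C2CC(N=[N+]=[N-])C(COC(=O)NCCCO)O2)c(=O)[nH]c1=O` carries a (3-hydroxypropyl)amino group on a carbonyl carbon of a carbamate-type side chain. In a functional assay on MT4 cells (Homo sapiens) for cytotoxicity (a lower number here means that less compound is tolerated, a higher number that more compound is tolerated), compound 3 gives > 50000 nM, and this is a limit of the assay rather than a measured number. Its two neighbours in the set stand in the same place. Compound 1 `Cc1cn(C2CC(N=[N+]=[N-])C(COC(=O)NCCCC(=O)O)O2)c(=O)[nH]c1=O` gives > 50000 nM in this assay, which is a limit. Compound 2 `Cc1cn(C2CC(N=[N+]=[N-])C(COC(=O)OCCO)O2)c(=O)[nH]c1=O` gives > 50000 nM in this assay, again a limit. The steps between them therefore carry no size: a step that the two limits leave unreadable from compound 1 to compound 3, a step that the two limits leave unreadable from compound 1 to compound 2 and a step that the two limits leave unreadable from compound 2 to compound 3, all resting on (the limit of > 50000 nM in this assay, at which 3 of the 3 values shown sit).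

For the measured compounds named here, compound 4 `Cc1cn(C2CC(N=[N+]=[N-])C(COC(=O)OCCCCCO)O2)c(=O)[nH]c1=O` is the next member. (5-hydroxypentyl)oxy in place of (3-hydroxypropyl)amino on a carbonyl carbon None of the measured steps can show a direction for this change, so no step beyond the scatter is expected. Compound 4 is therefore expected to reach about 50000 nM, in the range 25000 nM to 200000 nM, most probably reported again as a limit. The expected step is a number no higher from compound 3 to compound 4 (the limit leaves the size open).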

Compound 4, half-maximal cytotoxic concentration: > 50000 nM
Compound 4: a limit, no number; the forecaster's own chance of this, stated with the estimate: 85%; the middle value lies on the limit itself.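

For the compounds shown here, compound 4 ends at a limit, as do compound 1, compound 2 and compound 3, so no step to compound 4 can be read: the limit of > 50000 nM in this assay, at which 4 of the 4 values shown sit. The compounds shown leave open where each one's true cytotoxic concentration lies in this assay, and so whether these side chains differ at all.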